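Dimethoxy chalcone analogue in the series

A few compounds are considered here, and "the series" means these few. Any claim that something is new, unique, unknown or untested is made for them only; others in the source may bear on it.

Compound 2 `COc1ccc(/C=C/C(=O)c2ccc(NC(=O)CN3CCN(c4cc5c(cc4F)c(=O)c(C(=O)O)cn5C4CC4)CC3)cc2)cc1` gives the higher of the two numbers measured in a physicochemical assay for lipophilicity, using the shake flask method, in phosphate buffer, measured as octanol-water partition, with a stated time of 5 h (a higher number here means a more lipophilic compound, a lower number a more polar compound), at 0.684. Among the measured compounds shown here, compound 1 `O=C(CN1CCN(c2cc3c(cc2F)c(=O)c(C(=O)O)cn3C2CC2)CC1)Nc1ccc(C(=O)/C=C/c2cccc(Cl)c2)cc1` stands nearest, and in this assay compound 1 gives 0.302; the one measured step is a number 0.38 log units higher from compound 1 to compound 2 (beyond the scatter). Compound 3 `COc1ccc(/C=C/C(=O)c2ccc(NC(=O)CN3CCN(c4cc5c(cc4F)c(=O)c(C(=O)O)cn5C4CC4)CC3)cc2)cc1OC` has not been measured. It differs from compound 2 by methoxy in place of hydrogen on an aromatic carbon. For the measured compounds named here, no measured step bears on this change directly: the only step in the set exchanges one aryl group for another and does not add a methoxy group to an aromatic carbon that carried hydrogen. On the evidence of the two measured compounds alone, the expected step of a number 0.08 log units lower from compound 2 to compound 3 (within the scatter) is small, with no direction established beyond the scatter. For compound 3 the expected partition coefficient in this assay is therefore 0.6, within a range from 0.2 to 1.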

Compound 3, partition coefficient: 1.46
For compound 3 the middle estimate is 0.86 log units below the measured one; the measured number lies above the stated range.
By their numbers in this assay, from the lowest: compound 1; then compound 2; then compound 3.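

In this assay, among the compounds shown here, the step from adding methoxy on an aromatic carbon, ortho to a methoxy group and meta to a large group, is a number 0.78 log units higher from compound 2 to compound 3 (beyond the scatter) and gives the first reading of an addition at this position, since the earlier step only exchanged one aryl group for another. With 3,4-dimethoxyphenyl in place of 3-chlorophenyl the exchange gives a number 1.16 log units higher from compound 1 to compound 3 (beyond the scatter) and now spans the widest gap in the set, so 4-methoxyphenyl no longer marks the top of the series. No measurement at hand accounts for the size of either step.

From the compounds shown here alone, whether an ethoxy group, a hydroxyl or an amine on the same aromatic carbon would move the number in the same direction remains open. Also open, going by these compounds, is whether methoxy added to the 3-chlorophenyl group of compound 1 would give a step of similar size.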